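This account rests on a few compounds, and the source may have more. Where it says the series, first, only, none or still open, it means among the compounds named here.

Compound 1, `CC1C[C@H](OCCOC(=O)c2cnc3ccccc3n2)CC(O)C1O[C@H]1CC(N)C(O)C(C)O1`: 65000 nM
Compound 2, `CC1O[C@H](OC2C(O)C[C@H](OCCOC(=O)c3cnc4ccccc4n3)OC2C)CC(N)C1O`: 43000 nM

Of the compounds shown here, two have been measured in a functional assay with Nucleic Acid as the target; on this read-out higher numbers stand for lower toxicity in this test and lower numbers for higher toxicity in this test. Compound 1 gives 65000 nM and compound 2 gives 43000 nM. Compound 1 has the higher of the two numbers, but the gap to compound 2 lies within the usual scatter of this assay, so the two values cannot be told apart.

Compound 3, `CC1C[C@@H](OCCOC(=O)c2cnc3ccccc3n2)CC(O)C1O[C@H]1CC(N)C(O)C(C)O1`, has not been measured yet. It differs from compound 1 only in stereochemistry: the two compounds have the same atoms and bonds; at least one stereo element is drawn with a configuration in one of them and without one in the other: 1 of 8 stereo elements differ; a stereocentre at a saturated ring carbon is drawn S in compound 1 and R in compound 3. Going by the values given here, no step between measured compounds exists to show what such a change does to this assay. With no guide, a modest step at most is expected, in no fixed direction, and most likely none beyond the scatter. The step from compound 1 to compound 3 is therefore expected to be a 1.1-fold lower number from compound 1 to compound 3 (0.03 log units; within the scatter). Compound 3 is thus estimated at 60000 nM, with a range from 25000 nM to 150000 nM.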

Compound 3, half-maximal cytotoxic concentration: 25000 nM
The estimate for compound 3 lay 2.4-fold (0.38 log units) above the measured number, within the range that was stated.
By their numbers in this assay, from the lowest: compounds 3, 2 and 1 (each within the scatter of the next, the first and the last beyond it).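

The earlier compounds offered no step between measured pairs, so nothing had shown how this position responds to a change. In this assay, turning this one saturated ring carbon from S to R gives a 2.6-fold lower number from compound 1 to compound 3 (0.41 log units; beyond the scatter), a shift toward higher toxicity in this test with the atoms and bonds unchanged, so configuration alone at this stereocentre can move the read-out. One point limits how cleanly the step can be assigned to a pure exchange of S for R: the fact that one of compounds 1 and 3 is drawn with a defined configuration and the other without, at the place where they differ

The compounds shown leave open whether the other stereo elements of the shared core matter to a similar degree. They also leave open whether the step would keep its size and direction with an amide or a longer chain in the side arm.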